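From compound 2 to compound 3: an ester side chain

This account rests on a few compounds, and the source may have more. Where it says the series, first, only, none or still open, it means among the compounds named here.

In a functional assay on cells (Endothelial cell) for inhibition (on this read-out lower numbers stand for stronger inhibition and higher numbers for weaker inhibition), compound 1 (`CC(C)(C)c1cc(-c2cc(=O)c3ccc(OCC(=O)O)cc3o2)cc(C(C)(C)C)c1O`) gives 500 nM and compound 2 (`CCOC(=O)COc1ccc2c(=O)cc(-c3cc(C(C)(C)C)c(O)c(C(C)(C)C)c3)oc2c1`), its ethyl ester, gives 800 nM. Within the data shown here, compound 2 therefore cannot be told apart from compound 1, the only measured step being a 1.6-fold higher number from compound 1 to compound 2 (0.20 log units; within the scatter) in this pair. Compound 3 (`CCOC(=O)C(C)(C)Oc1ccc2c(=O)cc(-c3cc(C(C)(C)C)c(O)c(C(C)(C)C)c3)oc2c1`) carries 1-(ethoxycarbonyl)-1-methylethyl in place of (ethoxycarbonyl)methyl on an oxygen on an aromatic ring. Among the measured compounds shown here, no measured step covers this change directly. For the measured compounds named here, the one available step concerned the ethyl group of the ester and stayed small, so it offers only weak guidance, and no direction is favoured. The expected outcome in this assay is no change at the digits printed from compound 2 to compound 3 (within the scatter) with no shift beyond the scatter anticipated. Compound 3 is estimated at 800 nM (expected range 300 nM to 2200 nM).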

Compound 3, half-maximal inhibitory concentration: 500 nM
Beside the measured number, compound 3's estimate is 1.6-fold (0.20 log units) above it; measured number inside the range.
By their numbers in this assay, from the lowest: compounds 1, 3 and 2 (each within the scatter of the next).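

In this assay the oxygen on an aromatic ring takes 1-(ethoxycarbonyl)-1-methylethyl in place of (ethoxycarbonyl)methyl with a 1.6-fold lower number from compound 2 to compound 3 (0.20 log units; within the scatter) and so, unlike the earlier step at the ethyl group of the ester, this one shows that the chain attached to that oxygen can be altered without a shift beyond the scatter. The comparison with the acid points the same way: there is no change at the digits printed from compound 1 to compound 3 (within the scatter) and so carboxymethyl and 1-(ethoxycarbonyl)-1-methylethyl cannot be told apart at this position. No supporting measurement bears on these results.

As far as these compounds go, whether an amide, a longer chain or the carboxylic acid matching compound 3 would read differently on this oxygen stays open. So does whether any group there can move the number beyond the scatter, since compounds 1, 2 and 3 all lie within it.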